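Indole series: isopropenyl replacing chloro on the aryl ring

A few compounds are considered here, and "the series" means these few. Any claim that something is new, unique, unknown or untested is made for them only; others in the source may bear on it.

Measured compounds:
compound 1 `Brc1ccc2ccn(CCN3CCCN4CCCCC4C3)c2c1` — 3 nM
compound 2 `CN1CCCN(CCn2ccc3ccc(F)cc32)CC1` — 288 nM
compound 3 `CN1CCCN(CCn2ccc3ccc(Cl)cc32)CC1` — 34 nM

All three were run in an assay on HEK293 cells for binding affinity to 5-hydroxytryptamine receptor 7 (Homo sapiens), read by radioligand binding; on this read-out higher numbers stand for weaker inhibition and lower numbers for stronger inhibition. Compound 3 stands second of the three numbers, behind compound 1 and ahead of compound 2. For the measured compounds named here, the one step in a single place, an 8.5-fold lower number from compound 2 to compound 3 (0.93 log units; beyond the scatter), is a modest gain beyond the scatter for a larger halogen.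

The next compound, compound 4 `C=C(C)c1ccc2ccn(CCN3CCCN(C)CC3)c2c1`, differs from compound 3 by 1-methylethenyl in place of chloro on an aromatic carbon. Going by the values given here, no measured step covers this replacement; only the halogen step from compound 2 to compound 3 bears on it, and it says little about a carbon group of this shape. A change within or near the scatter in this assay is expected, roughly a 1.4-fold lower number from compound 3 to compound 4 (0.13 log units; within the scatter). Compound 4 is therefore estimated at 25 nM, with a range of 6 nM to 110 nM.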

Compound 4, inhibition constant: 70 nM
Compound 4: the middle estimate sits 2.8-fold (0.45 log units) below what was measured; low and high end bracket the measured number.
By their numbers in this assay, from the lowest: compound 1; then compound 3; then compound 4; then compound 2.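

In this assay, this aromatic carbon takes a non-halogen carbon group with only a limited loss against chloro, with a 2.1-fold higher number from compound 3 to compound 4 (0.31 log units; beyond the scatter), while 1-methylethenyl still improves on fluoro, with a 4.1-fold lower number from compound 2 to compound 4 (0.61 log units; beyond the scatter). The order at this place is therefore chloro, then 1-methylethenyl, then fluoro, and it does not track heavy-atom count, since the three-carbon group falls short of the single chlorine. No measured evidence accounts for this order.

Open, on these data alone, is whether isopropyl, the saturated counterpart of 1-methylethenyl, would sit nearer chloro or fluoro. Methoxy and nitrile at this place also remain untested against the same core.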